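Series notes: from compound 3 to compound 4

The source may hold more compounds than are shown below. What is called first, only, known or untested is meant among the compounds shown, and "the series" means these compounds.

Measured in a functional assay on A-427 cells (Homo sapiens) for cytotoxicity, read by colorimetric assay and MTT assay (on this read-out higher numbers stand for weaker inhibition and lower numbers for stronger inhibition), so far
- compound 1 `COc1cc(OC)c2cc(-c3ccc(OCc4ccccc4)cc3)c(O)nc2c1` gives 10000 nM
- compound 2 `CCN(CC)C(=O)Cn1c(=O)c(-c2ccc(OC)cc2)cc2c(OC)cc(OC)cc21` gives 10000 nM
- compound 3 `COc1ccc(-c2cc3c(OC)cc(OC)cc3n(CC(=O)O)c2=O)cc1` gives 10000 nM

Compound 1 and compound 2 stand level with compound 3, which holds 10000 nM in this assay with no separation among the three. The next structure is compound 4 `CCN(CC)C(=O)CCn1c(=O)c(-c2ccc(OC)cc2)cc2c(OC)cc(OC)cc21`, reached by (diethylcarbamoyl)methyl in place of carboxy on a saturated chain carbon bound to an aromatic nitrogen. Going by the values given here, the one measured step that bears on this is no change at the digits printed from compound 2 to compound 3 (within the scatter), which exchanges hydroxy and diethylamino on a carbonyl carbon. Among the compounds with values here, no measured compound carries the 2-(diethylcarbamoyl)ethyl group, so that part of the change is untested. The expected result is no change at the digits printed from compound 3 to compound 4 (within the scatter), with no movement beyond the scatter in either direction. Compound 4 is estimated at 10000 nM, within an expected range of 4000 nM to 20000 nM.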

Compound 4, half-maximal inhibitory concentration: 10000 nM
The estimate for compound 4 equals the measured number at the digits printed, and the stated range covers the measured number.
By their numbers in this assay, from the lowest: compounds 1, 2, 3 and 4 (each within the scatter of the next).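

In this assay, (diethylcarbamoyl)methyl in place of carboxy on a saturated chain carbon bound to an aromatic nitrogen gives no change at the digits printed from compound 3 to compound 4 (within the scatter) and so does not separate the amide from the acid at this longer chain. (Diethylcarbamoyl)methyl in place of diethylcarbamoyl at the same place gives no change at the digits printed from compound 2 to compound 4 (within the scatter) and so adds a chain extension to the exchanges that leave the printed value in place. No measured evidence on the cause of these equal values is available.

From the compounds shown here alone, whether a basic amine such as dimethylamino or a still longer chain at this place would give a value apart from the others stays open.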